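This account rests on a few compounds, and the source may have more. Where it says the series, first, only, none or still open, it means among the compounds named here.

Measured in an ADME assay on MT4 cells (Homo sapiens) for activation, read by MTT assay; on this read-out higher numbers stand for lower toxicity in this test and lower numbers for higher toxicity in this test:

Compound 1 `CC(C)Sc1nc(C(C)c2c(F)cccc2Cl)cc(=O)[nH]1`: > 75000 nM
Compound 2 `CCC(C)Sc1nc(C(C)c2c(F)cccc2Cl)cc(=O)[nH]1`: > 73000 nM

Compound 2 stands only at a limit, > 73000 nM, and has no numerical value. Compound 1 is likewise known only by a limit, > 75000 nM. Compound 3 `CC(c1cc(=O)[nH]c(SC2CCCC2)n1)c1c(F)cccc1Cl` has cyclopentyl in place of sec-butyl on a sulfur. Among the compounds with values here, the only measured step bearing on this change is a step that the two limits leave unreadable from compound 1 to compound 2, so it gives no size to carry over. No change beyond the usual scatter is therefore expected in this assay, and the estimated step is an at least 1.2-fold lower number from compound 2 to compound 3 (0.08 log units; that floor lies within the scatter). Compound 3 is expected at 60000 nM, with an estimated range from 20000 nM to 120000 nM.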

Compound 3, half-maximal cytotoxic concentration: > 71000 nM
Compound 3: no number, only a limit; the forecaster's own chance of this, stated with the estimate: 65%; middle value at least 1.1-fold (0.07 log units) away from the limit.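

In this assay, within the data shown here, compound 1, compound 2 and compound 3 are each known only by a limit, so no step among them can be read. The compounds shown leave open whether isopropyl, sec-butyl and cyclopentyl on the sulfur differ at all in this read-out.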